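Swapping the Aryl Amide Tail for a Cyclohexyl

The source may report more compounds than this note shows. Statements on the series, on what has been measured and on what is new or still open speak of the compounds shown alone.

In an ADME assay on MT2 cells (Homo sapiens) for cytotoxicity (a higher number here means that more compound is tolerated, a lower number that less compound is tolerated), compound 2 (`Cc1nc2cc(C(=O)NCc3ccc(F)cc3-n3cncn3)nn2c(-c2cc(F)c3c(c2C)CCCO3)c1[C@H](OC(C)(C)C)C(=O)O`) gives only > 40000 nM, a limit of the assay rather than a number. Its neighbour compound 1 (`COc1cc(F)ccc1CNC(=O)c1cc2nc(C)c([C@H](OC(C)(C)C)C(=O)O)c(-c3cc(F)c4c(c3C)CCCO4)n2n1`) likewise gives only the limit > 40000 nM in this assay. Between them lies a step that the two limits leave unreadable from compound 1 to compound 2, so that step cannot be read. Both values therefore rest together on (the limit of > 40000 nM in this assay, at which 2 of the 2 values shown sit).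

Compound 3 (`Cc1nc2cc(C(=O)NCC3CCCCC3)nn2c(-c2cc(F)c3c(c2C)CCCO3)c1[C@H](OC(C)(C)C)C(=O)O`) has not been measured yet. It differs from compound 2 in one place: cyclohexyl in place of 4-fluoro-2-(1H-1,2,4-triazol-1-yl)phenyl on a saturated chain carbon bound to an amide-type nitrogen. No measured step covers this change, and the only comparison shown, from compound 1 to compound 2, is unreadable with both ends at the limit, so no movement beyond the scatter can be expected in either direction. The expected step is therefore a number no higher from compound 2 to compound 3 (the limit leaves the size open). Compound 3 is expected near 40000 nM, within 20000 nM to 80000 nM, and most likely reported again only as a limit.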

Compound 3, half-maximal cytotoxic concentration: > 40000 nM
Compound 3 was reported as a limit; the forecaster's own chance of this, stated with the estimate: 85%; the middle value lies on the limit itself.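

Compound 3 gives > 40000 nM, again a limit of the assay and not a number. No step among compound 1, compound 2 and compound 3 can be read: the limit of > 40000 nM in this assay, at which 3 of the 3 values shown sit.

The compounds shown leave open at what concentration any of them turns cytotoxic, and whether changing the amide tail shifts that concentration.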